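The source may hold more compounds than are shown below. What is called first, only, known or untested is meant among the compounds shown, and "the series" means these compounds.

Measured compounds:
Compound 1, `CCN(CC)CCNC(=O)c1ccc(C(CC)(CC)c2ccc(OCC(O)C(C)(C)C)c(C)c2)n1CC`: 110 nM
Compound 2, `CCn1c(C(=O)N(CCC#N)CCC#N)ccc1C(CC)(CC)c1ccc(OCC(O)C(C)(C)C)c(C)c1`: 97 nM

Compound 2 stands lowest of the two numbers in an assay on HL-60 cells for agonist activity at vitamin D3 receptor (Homo sapiens), read by microscopy, with a stated time of 96 h (a lower number here means that less compound is needed, a higher number that more compound is needed for the effect), but the difference to compound 1 is within the scatter, so the two cannot be ranked. Among the compounds with values here, the step is a 1.1-fold lower number from compound 1 to compound 2 (0.05 log units; within the scatter), and it is the only measured step; it changes the substituent on the same carbonyl carbon that compound 3 alters. Compound 3, `C#CCCOC(=O)c1ccc(C(CC)(CC)c2ccc(OCC(O)C(C)(C)C)c(C)c2)n1CC`, is not yet measured. It carries a group of 5 heavy atoms (4 carbon, 1 oxygen; no ring) in place of a group of 9 heavy atoms (6 carbon, 3 nitrogen; no ring), on a carbonyl carbon. Within the data shown here, the one measured step at this carbonyl carbon was within the scatter, yet it kept an amide, whereas compound 3 becomes an ester, which no measured pair tests. The account therefore expects a small step, if any, and leans toward a somewhat higher number, with wide uncertainty. Compound 3 is estimated at 150 nM, in the range 50 nM to 500 nM. The expected step is a 1.5-fold higher number from compound 2 to compound 3 (0.19 log units; within the scatter).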

Compound 3, half-maximal effective concentration: 1030 nM
For compound 3 the middle estimate is 6.9-fold (0.84 log units) below the measured one, outside the stated range (above it).
By their numbers in this assay, from the lowest: compounds 2 and 1 (each within the scatter of the next); then compound 3.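

Within the data shown here, until now, the only measured step at this carbonyl carbon, between two amides, had stayed within the scatter, so the position could have seemed tolerant of change. Placing (but-3-yn-1-yl)oxy there gives a step well beyond the scatter in this assay, with an 11-fold higher number from compound 2 to compound 3 (1.03 log units; beyond the scatter) and a 9.4-fold higher number from compound 1 to compound 3 (0.97 log units; beyond the scatter). This shows that the group on this carbonyl carbon can matter to the number, and that the two different amide groups, while within the scatter of each other, do not define the full range at this position; nothing available accounts for the rise.

The compounds shown do not separate the ester oxygen from the but-3-yn-1-yl chain, as that chain appears only on the ester. On these data alone, how a carboxylic acid or a simple methyl ester on this carbonyl carbon would stand in this assay also remains open.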